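The compounds below may be only part of what the source reports. "The series", "measured", "known", "first", "only" and "open" are said of these compounds alone.

Measured compounds:
Compound 1 `CNc1nccc(N2CC[C@H](NC(=O)Nc3ccc(Cl)c(C(F)(F)F)c3)C2)n1` gives 10.1 nM in an assay on a protein complex for displacement of a labelled ligand from CDK8/Cyclin C (Homo sapiens), read by TR-FRET, with a stated time of 1 h; a lower number here means a stronger inhibitor, a higher number a weaker inhibitor.
Compound 2 `CNc1nccc(N2CC[C@H](NC(=O)Nc3ccc(OC(F)(F)F)cc3)C2)n1` gives 44.1 nM in this assay.
Compound 3 `O=C(Nc1ccc(Cl)c(C(F)(F)F)c1)N[C@H]1CCN(c2ccc3nncn3n2)C1` gives 4.2 nM in this assay.

Compound 3 stands lowest of the three numbers in this assay; compound 1 is nearest to it, and compound 2 lies furthest away. The one measured step that joins two of these compounds is the exchange on the ring amine nitrogen, which gave a 2.4-fold lower number from compound 1 to compound 3 (0.38 log units; beyond the scatter).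

Compound 4 `O=C(Nc1ccc(Cl)c(C(F)(F)F)c1)N[C@@H]1CCN(c2ccc3nncn3n2)C1` is the other configuration of compound 3: the two compounds have the same atoms and bonds and differ only in configuration as drawn: 1 of 1 stereo elements differ; a stereocentre at a saturated ring carbon is drawn S in compound 3 and R in compound 4. Within the data shown here, no measured step bears on this change. Among the measured compounds shown here, the one step in this assay concerned a replacement of a ring group, not a change of configuration, so it says nothing about what turning the stereocentre will do. Compound 2 differs from compound 1 in a different place and helps no further. The account therefore rests on the general observation that two configurations of the same compound seldom give the same number, and that a number higher than that of compound 3 is the more common outcome. Compound 4 is thus expected to give a weaker result, estimated as a 12-fold higher number from compound 3 to compound 4 (1.08 log units; beyond the scatter), though with a wide range. Compound 4 is estimated at 50 nM in this assay, between 4 nM and 600 nM.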

Compound 4, half-maximal inhibitory concentration: 166 nM
Compound 4: middle estimate off by 3.3-fold (0.52 log units), on the low side; the measured number falls inside the stated range.
By their numbers in this assay, from the lowest: compound 3; then compound 1; then compound 2; then compound 4.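

In this assay, the configuration at the saturated ring carbon proves to matter a great deal: turning the stereocentre from S to R gives a 40-fold higher number from compound 3 to compound 4 (1.60 log units; beyond the scatter). Among these compounds, the only earlier step between compounds differing in one place, a 2.4-fold lower number from compound 1 to compound 3 (0.38 log units; beyond the scatter), was a modest change on the ring amine nitrogen and said nothing about this stereocentre, whereas this step is large and shows that the S configuration drawn in compound 3 gives the far lower number of the pair. The whole of this shift can be laid to the stereocentre, because nothing else separates the pair: the fact that compounds 3 and 4 differ only in the configuration as drawn.

Only one such pair of configurations is shown, so it stays open whether the S configuration holds the same advantage with the group that compound 1 carries on the ring amine nitrogen, or with the aryl group of compound 2. Also open, going by these compounds, is how the number would respond to a carboxylic acid or a longer chain on that ring amine nitrogen in either configuration.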